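The compounds below may be only part of what the source reports. "The series", "measured", "known", "first", "only" and "open" are said of these compounds alone.

In a toxicity assay on HUVEC cells (Homo sapiens) for inhibition (a lower number here means a stronger inhibitor of growth, a higher number a weaker inhibitor of growth), compound 1 `Cc1nc(-c2ccccc2)c(C(=O)N2CCN(c3cccc(Cl)c3)CC2)o1` gives 0.463 ug/mL and compound 2 `Cc1nc(-c2ccccc2)c(C(=O)N2CCN(c3cccc(C)c3C)CC2)o1` gives 0.38 ug/mL. Going by the values given here, the only measured step, a 1.2-fold lower number from compound 1 to compound 2 (0.09 log units; within the scatter), lies within the scatter, so compound 2 stands level with compound 1. Compound 3 `Cc1ccc(C)c(N2CCN(C(=O)c3oc(C)nc3-c3ccccc3)CC2)c1` keeps the shared core and differs from compound 2 in one group: 2,5-dimethylphenyl in place of 2,3-dimethylphenyl on an amine nitrogen in a ring. Among the compounds with values here, no measured step shows this exact exchange, and the nearest one, at the same amine nitrogen, is a 1.2-fold lower number from compound 1 to compound 2 (0.09 log units; within the scatter). No shift beyond the scatter is therefore expected in this assay. The expected step is a 1.1-fold higher number from compound 2 to compound 3 (0.02 log units; within the scatter). Compound 3 is estimated at 0.4 ug/mL, with an expected range of 0.2 ug/mL to 0.8 ug/mL.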

Compound 3, concentration for 50% growth inhibition: 1.73 ug/mL
Beside the measured number, compound 3's estimate is 4.3-fold (0.64 log units) below it, outside the stated range (above it).
By their numbers in this assay, from the lowest: compounds 2 and 1 (each within the scatter of the next); then compound 3.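

In this assay the exchange keeps the same atoms and only rearranges the two methyl groups on the phenyl at this amine nitrogen, yet it gives a 4.6-fold higher number from compound 2 to compound 3 (0.66 log units; beyond the scatter), whereas the earlier step stayed within the scatter. The change from a chlorine-bearing phenyl gives a 3.7-fold higher number from compound 1 to compound 3 (0.57 log units; beyond the scatter), so the 2,5-dimethylphenyl makes compound 3 the weakest inhibitor of growth of the three. Nothing available explains this shift. The compounds shown leave open whether a single methyl group or a methoxy group on that phenyl would stay level with compound 1 and compound 2.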